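Carbamate in place of the difluorophenyl amide on the pyrazole core

The source may hold more compounds than are shown below. What is called first, only, known or untested is meant among the compounds shown, and "the series" means these compounds.

Compound 1 `Cc1cc(C(=O)Nc2c(F)cccc2F)nn1Cc1cc(Cl)ccc1OCc1ccccc1` gives 3.7 in a physicochemical assay for lipophilicity, at pH 7.4; on this read-out lower numbers stand for lower lipophilicity and higher numbers for higher lipophilicity; of the two plain numbers in this series it stands highest, and its nearest neighbour is compound 2 `Cc1cc(NC(=O)CC2CCCCC2)nn1Cc1cc(Cl)ccc1OCc1ccccc1`, which gives 3.2, a change of a number 0.50 log units lower from compound 1 to compound 2 (beyond the scatter). Compound 3 `Cc1cc(NC(=O)C2CCOCC2)nn1Cc1cc(Cl)ccc1OCc1ccccc1` is reported only as a limit, > 3.7, so the size of the step from compound 1 is not readable there: a number no lower from compound 1 to compound 3 (the limit leaves the size open). Between the two amides the step is a number at least 0.50 log units higher from compound 2 to compound 3 (beyond the scatter), which again rests on the limit (the limit of > 3.7 in this assay, at which 1 of the 3 values shown sits).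

Compound 4 `COC(=O)Nc1cc(C)n(Cc2cc(Cl)ccc2OCc2ccccc2)n1` is not yet measured. The change from compound 1 is (methoxycarbonyl)amino in place of (2,6-difluorophenyl)carbamoyl on an aromatic carbon. Among the compounds with values here, of the measured steps, the one from compound 1 to compound 2 is the closest model, since it also replaces the (2,6-difluorophenyl)carbamoyl group with a group bearing a carbonyl on the same aromatic carbon, and it moved this assay by a number 0.50 log units lower from compound 1 to compound 2 (beyond the scatter). The step to compound 3 gives no direction beyond "not lower". The value of compound 3 is a limit. On this basis compound 4 is expected to fall below compound 1 by a modest margin, an estimated step of a number 0.70 log units lower from compound 1 to compound 4 (beyond the scatter). For compound 4 the estimate in this assay is 3, with a range from 2.4 to 3.6.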

Compound 4, distribution coefficient: > 3.7
Compound 4 ended at the assay's limit (the forecaster's own chance of this, stated with the estimate: 5%); middle value at least 0.70 log units from the limit.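

Replacing the (2,6-difluorophenyl)carbamoyl group with (methoxycarbonyl)amino on this aromatic carbon, next to the ring nitrogen, takes the substituent from 11 heavy atoms and an aromatic ring to 5 heavy atoms and no ring, yet in this assay the result is a number no lower from compound 1 to compound 4 (the limit leaves the size open). Methoxy in place of cyclohexylmethyl on the carbonyl carbon gives a number at least 0.50 log units higher from compound 2 to compound 4 (beyond the scatter), in the same direction as the oxan-4-yl change, so among the three compounds with a carbonyl-bearing amino group at this position, compound 2 is the only one with a plain number. The step from compound 3 to compound 4 cannot be read, because both compounds rest on the same limit: the limit of > 3.7 in this assay, at which 2 of the 4 values shown sit.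

Going by these compounds, how far compound 4 lies beyond compound 1 remains open, as does any order between compound 3 and compound 4. Also open, on these data alone, is how an amine or a carboxylic acid on this aromatic carbon, or ethoxy in place of methoxy on the carbonyl carbon, would read in this assay.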